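This account rests on a few compounds, and the source may have more. Where it says the series, first, only, none or still open, it means among the compounds named here.

Measured so far in a functional assay on SK-N-SH cells (Homo sapiens) for cytotoxicity, read by sulforhodamine B assay, with a stated time of 48 h; on this read-out higher numbers stand for weaker inhibition and lower numbers for stronger inhibition:
compound 1 `CO[C@@H]1CC=C2NN(c3ccc(C)cc3)C(=O)CC[C@]2(c2ccccc2)O1` gives 1700 nM;
compound 2 `CO[C@@H]1CC=C2NN(c3ccc([N+](=O)[O-])cc3)C(=O)CC[C@]2(c2ccccc2)O1` gives 7300 nM;
compound 3 `CO[C@@H]1CC=C2N(c3ccc(C)cc3)C(=O)C[C@]2(c2ccccc2)O1` gives 3500 nM.

Compound 1 and compound 2 share one core and differ only at the aromatic ring: nitro in place of methyl on an aromatic carbon. That change made the step of a 4.3-fold higher number from compound 1 to compound 2 (0.63 log units; beyond the scatter), a weakening of growth inhibition. Compound 3 has a different core; how the two cores differ is not broken down here. Compound 4 `CO[C@@H]1CC=C2N(c3ccc([N+](=O)[O-])cc3)C(=O)C[C@]2(c2ccccc2)O1` is not yet measured and stands to compound 3 as compound 2 stands to compound 1: nitro in place of methyl on an aromatic carbon, the same change at the same place. Because the earlier step of a 4.3-fold higher number from compound 1 to compound 2 (0.63 log units; beyond the scatter) lay beyond the usual scatter, a step of similar size is expected from compound 3 to compound 4, namely a 4.3-fold higher number from compound 3 to compound 4 (0.63 log units; beyond the scatter). Compound 4 is therefore estimated at 15000 nM, expected to fall between 6000 nM and 40000 nM.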

Compound 4, half-maximal inhibitory concentration: 9400 nM
Estimate against measurement, compound 4: 1.6-fold (0.20 log units) above; the range from low to high includes it.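

In this assay the swap of 4-methylphenyl to 4-nitrophenyl on the core of compound 3 gave a 2.7-fold higher number from compound 3 to compound 4 (0.43 log units; beyond the scatter) and so again weakened growth inhibition. The two steps run the same way, and their sizes cannot be told apart: the same change on two cores in this assay, a 4.3-fold higher number (0.63 log units; beyond the scatter) from compound 1 to compound 2 and a 2.7-fold higher number (0.43 log units; beyond the scatter) from compound 3 to compound 4, 1.6-fold (0.20 log units) apart, within the scatter of two such steps. This shows that the change carried over between these two cores, but two pairs in one cell line do not show that it would hold on any other core, and they do not explain why the numbers rise.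

Still open, as far as these compounds go, is what other groups at this place on the aromatic ring would do, such as an amine, a carboxylic acid or a longer chain. Also open, from the compounds shown here alone, is whether changes to the methoxy group or the phenyl group on the core would carry over in the same way.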